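Methoxy to Chloro on an Aryl Piperazine Series

This account rests on a few compounds, and the source may have more. Where it says the series, first, only, none or still open, it means among the compounds named here.

compound 1, `COc1ccccc1N1CCN(CCCCn2nc(-n3cnc4ccccc43)ccc2=O)CC1`, in an assay on cell membranes from brain for binding affinity to Adrenergic receptor alpha-1 (Rattus norvegicus), read by radioligand binding (on this read-out lower numbers stand for stronger inhibition and higher numbers for weaker inhibition), compound 1 gives 1.1 nM
compound 2, `O=c1ccc(-n2cnc3ccccc32)nn1CCCCN1CCN(c2ccccc2Cl)CC1`, compound 2 gives 1.3 nM
compound 3, `COc1ccccc1N1CCN(CCCCCCn2nc(-n3ccnc3)ccc2=O)CC1`, compound 3 gives 52.5 nM

Compounds 1 and 2 share one core and differ in a single place: chloro in place of methoxy on an aromatic carbon. This change produced a 1.2-fold higher number from compound 1 to compound 2 (0.07 log units; within the scatter), so the two values cannot be told apart. Compound 3 has a different core, and the difference between the two cores is not broken down here; what the values show is that compound 3 stands well apart from both compound 1 and compound 2 on this assay. Compound 4, `O=c1ccc(-n2ccnc2)nn1CCCCCCN1CCN(c2ccccc2Cl)CC1`, is not yet measured and differs from compound 3 by chloro in place of methoxy on an aromatic carbon. The place lines read the same word for word in both pairs, so this is the same change that was made from compound 1 to compound 2. For compound 4 the step from compound 3 is expected to be a 1.1-fold higher number from compound 3 to compound 4 (0.06 log units; within the scatter) because a 1.2-fold higher number from compound 1 to compound 2 (0.07 log units; within the scatter) lay within the scatter, although a single precedent on another core is a thin basis. Compound 4 is therefore estimated at 60 nM, with a likely range from 20 nM to 180 nM.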

Compound 4, inhibition constant: 29.7 nM
For compound 4 the middle estimate is 2.0-fold (0.31 log units) above the measured one; the range from low to high includes it.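

In this assay, replacing 2-methoxyphenyl with 2-chlorophenyl on the second core gave a 1.8-fold lower number from compound 3 to compound 4 (0.25 log units; within the scatter), so this step, like the earlier one, cannot be told from repeated-measurement scatter. Set side by side, the two steps do not differ measurably: the same change on two cores in this assay, a 1.2-fold higher number (0.07 log units; within the scatter) from compound 1 to compound 2 and a 1.8-fold lower number (0.25 log units; within the scatter) from compound 3 to compound 4, 2.1-fold (0.32 log units) apart, within the scatter of two such steps. This shows that the change had no readable effect on either of these two cores, but it does not show that the two cores respond identically, and two pairs say nothing about any further core in the series.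

The compounds shown leave open how a fluoro or an amino group would read at this same place on either core. They also leave open which part of the difference between the core of compound 1 and the core of compound 3 accounts for the wide gap between their values, as those two compounds differ in more than one place.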